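The compounds below may be only part of what the source reports. "The series", "measured", "known", "first", "only" and "open" are said of these compounds alone.

Measured in a functional assay on RKO cells (Homo sapiens) for cytotoxicity, read by resazurin assay, with a stated time of 72 h; a higher number here means a weaker inhibitor, a lower number a stronger inhibitor:
- compound 1 `c1ccc(Nc2nc(-n3cnc4ccccc43)cs2)cc1`: > 100000 nM (a limit)
- compound 2 `c1ccc(Nc2nc(-n3ccnc3)cs2)cc1`: > 100000 nM (a limit)

Neither compound gives a number in this assay. Compound 1 stands at the limit of > 100000 nM in this assay, at which 2 of the 2 values shown sit.

The next compound, compound 3 `COc1ccc(Nc2nc(-n3cnc4ccccc43)cs2)cc1`, differs from compound 1 in one place: methoxy in place of hydrogen on an aromatic carbon. This is methoxy in place of hydrogen on an aromatic carbon of a six-membered aromatic ring of carbon only, para to a large group.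

Going by the values given here, the series holds no measured step for this change, so there is no direct guide to its size. With compound 1 at the limit of > 100000 nM in this assay, at which 2 of the 2 values shown sit, the expectation in this assay is no step beyond the scatter, or at most a small one towards stronger inhibition. The estimated step is an at least 1.2-fold lower number from compound 1 to compound 3 (0.09 log units; that floor lies within the scatter). For compound 3 the estimated value is 80000 nM, with an expected range from 30000 nM to 100000 nM.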

Compound 3, half-maximal inhibitory concentration: > 100000 nM
Compound 3: no number, only a limit (the forecaster's own chance of this, stated with the estimate: 65%); middle value at least 1.2-fold (0.09 log units) away from the limit.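

Compound 1 and compound 3 both end at a limit, so no step can be read for methoxy in place of hydrogen on an aromatic carbon: the limit of > 100000 nM in this assay, at which 3 of the 3 values shown sit. The compounds shown leave open whether any change to the shared core gives a measurable value.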